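This account rests on a few compounds, and the source may have more. Where it says the series, first, only, none or still open, it means among the compounds named here.

Measured so far:
Compound 1 (`CC(C)c1ccc(-c2nc(SCc3cn(CC(=O)NC(=O)Nc4ccccn4)nn3)nc(Nc3ccc(F)cc3)c2C#N)cc1`) gives in a functional assay on ECa-109 cells (Homo sapiens) for inhibition, read by MTT assay, with a stated time of 72 h (a lower number here means a stronger inhibitor, a higher number a weaker inhibitor), only a limit of the assay, > 64000 nM.
Compound 2 (`CC(C)c1ccc(-c2nc(SCc3cn(CC(=O)NC(=O)Nc4ccccn4)nn3)nc(Nc3ccccc3F)c2C#N)cc1`) gives in this assay a value of 15500 nM.
Compound 3 (`Cc1ccc(Nc2nc(SCc3cn(CC(=O)NC(=O)Nc4ccccn4)nn3)nc(-c3ccc(C(C)C)cc3)c2C#N)cc1`) gives in this assay a value of 6700 nM.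

Among the two real numbers, compound 2 has the higher one; its nearest neighbour is compound 3, with a 2.3-fold lower number from compound 2 to compound 3 (0.36 log units; beyond the scatter). Compound 1 sits at the limit, as noted by the limit of > 64000 nM in this assay, at which 1 of the 3 values shown sits.

Compound 4 (`Cc1ccccc1Nc1nc(SCc2cn(CC(=O)NC(=O)Nc3ccccn3)nn2)nc(-c2ccc(C(C)C)cc2)c1C#N`) has not yet been measured. It differs from compound 2 by methyl in place of fluoro on an aromatic carbon. The same kind of exchange, fluoro for methyl on the aromatic ring attached to the nitrogen, is seen once among the measured compounds: an at least 9.5-fold lower number from compound 1 to compound 3 (0.98 log units; beyond the scatter). There the change sat at a different carbon of that ring, so it is a guide and not a copy. The move of the fluoro from one carbon to another, an at least 4.1-fold lower number from compound 1 to compound 2 (0.61 log units; beyond the scatter), shows that the position on this ring matters as well.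

Taken together, a lower number in this assay is expected for compound 4 than for compound 2, of roughly the size a 2.6-fold lower number from compound 2 to compound 4 (0.41 log units; beyond the scatter). Compound 4 is therefore estimated at 6000 nM, with a range from 2000 nM to 20000 nM.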

Compound 4, half-maximal inhibitory concentration: 7230 nM
The estimate for compound 4 lay 1.2-fold (0.08 log units) below the measured number; the measured number falls inside the stated range.
By their numbers in this assay, from the lowest: compounds 3 and 4 (each within the scatter of the next); then compound 2. At a limit, above all of these: compound 1.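

In this assay, methyl in place of fluoro on this aromatic carbon, ortho to a large group, again gives a lower number, a 2.1-fold lower number from compound 2 to compound 4 (0.33 log units; beyond the scatter), so the direction of the exchange seen at the other carbon recurs, though the size of the step does not carry over: the same change on two cores in this assay, an at least 9.5-fold lower number (0.98 log units; beyond the scatter) from compound 1 to compound 3 and a 2.1-fold lower number (0.33 log units; beyond the scatter) from compound 2 to compound 4, at least 4.4-fold (0.64 log units) apart, beyond the scatter of two such steps
With methyl on the ring, the two positions cannot be told apart, a 1.1-fold higher number from compound 3 to compound 4 (0.03 log units; within the scatter), whereas moving the fluoro gave an at least 4.1-fold lower number from compound 1 to compound 2 (0.61 log units; beyond the scatter), so the position mattered for the fluoro pair but not for the methyl pair.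
Compound 1 remains a limit of the assay, > 64000 nM, and the step of an at least 8.8-fold lower number from compound 1 to compound 4 (0.94 log units; beyond the scatter) is therefore only a floor and not a true size: the limit of > 64000 nM in this assay, at which 1 of the 4 values shown sits.

The compounds shown leave open whether a chlorine, a methoxy group or an amine on this carbon would read like the methyl or like the fluoro. They also leave open whether the methyl and fluoro steps would hold on a core that carries a carboxylic acid or a longer chain in place of the groups shared here.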